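A Substituted Aryl Swap on an Antiproliferative Core

The source may report more compounds than this note shows. Statements on the series, on what has been measured and on what is new or still open speak of the compounds shown alone.

Compounds measured so far:
compound 1, `O=C(Nc1ccc(Oc2ccnc3[nH]ccc23)cc1)c1cc2cccnc2n(-c2ccc(Cl)cc2)c1=O`, 280 nM in a functional assay on HT-29 cells (Homo sapiens) for antiproliferative activity, read by MTT assay, with a stated time of 72 h; a higher number here means a weaker inhibitor, a lower number a stronger inhibitor
compound 2, `O=C(Nc1ccc(Oc2ccnc3[nH]ccc23)cc1)c1cc2cccnc2n(-c2ccc(Br)cc2)c1=O`, 270 nM in this assay
compound 3, `O=C(Nc1ccc(Oc2ccnc3[nH]ccc23)c(F)c1)c1cc2cccnc2n(-c2ccc(Cl)cc2)c1=O`, 82 nM in this assay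

Compound 3 gives the lowest number of the three, and both compound 1 and compound 2 lie beyond the scatter above it. Among the compounds with values here, the only step that reaches compound 3 is a 3.4-fold lower number from compound 1 to compound 3 (0.53 log units; beyond the scatter), a modest gain from the fluoro group, which compound 4 keeps.

Compound 4 is `O=C(Nc1ccc(Oc2ccnc3[nH]ccc23)c(F)c1)c1cc2cccnc2n(-c2ccc(C(F)(F)F)cc2Cl)c1=O`. The change is 2-chloro-4-(trifluoromethyl)phenyl in place of 4-chlorophenyl on an aromatic nitrogen. Within the data shown here, no measured step covers a trifluoromethyl group or a second chloro on this ring. The nearest guide is a 1.0-fold lower number from compound 1 to compound 2 (0.02 log units; within the scatter), which swaps one halogen for another on the same ring and stays within the scatter, so that ring has tolerated one change there without effect. On that thin basis, a step of a 1.1-fold higher number from compound 3 to compound 4 (0.04 log units; within the scatter) is expected, that is nothing beyond the scatter. Compound 4 is therefore estimated at 90 nM, with a range from 30 nM to 300 nM.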

Compound 4, half-maximal inhibitory concentration: 1360 nM
Compound 4: middle estimate off by 15-fold (1.18 log units), on the low side; measured number above the stated range.
By their numbers in this assay, from the lowest: compound 3; then compounds 2 and 1 (each within the scatter of the next); then compound 4.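

In this assay, the group on the aromatic nitrogen turns out to matter: 2-chloro-4-(trifluoromethyl)phenyl in place of 4-chlorophenyl gives a 17-fold higher number from compound 3 to compound 4 (1.22 log units; beyond the scatter), whereas the earlier halogen swap on this ring gave only a 1.0-fold lower number from compound 1 to compound 2 (0.02 log units; within the scatter). The tolerance seen in that swap therefore does not extend to every change on this ring, and a flat result for one substitution proved a poor guide to a larger one. Nothing available here explains why the number rises so sharply.

Going by these compounds, the trifluoromethyl group and the second chloro enter together, so it remains open whether one of them alone accounts for the loss, and a ring carrying only one of them would separate the two. Also open, on these data alone, is how other groups on this ring, such as a methoxy group or an amine, would behave.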